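A Remote Aromatic Swap and the Acid Dissociation Constant

This account rests on a few compounds, and the source may have more. Where it says the series, first, only, none or still open, it means among the compounds named here.

Compound 1 `COc1ccc(F)cc1CNCCCNc1ccnc2cc(C3CCCCC3)ccc12`, compound 2 `COc1cccc(CNCCCNc2ccnc3cc(Cc4ccccc4)ccc23)c1O` and compound 3 `c1coc(CNCCCNc2ccnc3cc(C4CCCCC4)ccc23)c1` share one core and were all tested in a physicochemical assay for acid dissociation. There compound 1 gives 9.47, compound 2 gives 9.47 and compound 3 gives 9.47, so compound 1 stands level with both at the digits shown. Among the compounds with values here, the only step between compounds differing in a single place, no change at the digits printed from compound 1 to compound 3 (within the scatter), shows that swapping the group on the saturated chain carbon left the read-out untouched. Compound 4 `COc1ccc(F)cc1CNCCCNc1ccnc2cc(-c3ccc(C(F)(F)F)cc3)ccc12` differs from compound 1 elsewhere: 4-(trifluoromethyl)phenyl in place of cyclohexyl on an aromatic carbon. Within the data shown here, no measured step alters this part of the core, so there is no direct precedent. Among the measured compounds shown here, with every value so far identical, the step of a number 0.07 log units lower from compound 1 to compound 4 (within the scatter) is expected to stay within the scatter. Compound 4 is therefore estimated at 9.4, between 9.1 and 9.7.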

Compound 4, acid dissociation constant: 9.47
For compound 4 the middle estimate is 0.07 log units below the measured one; low and high end bracket the measured number.
By their numbers in this assay, from the lowest: compounds 1, 2, 3 and 4 (each within the scatter of the next).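

In this assay, within the data shown here, the step of no change at the digits printed from compound 1 to compound 4 (within the scatter) gives the first reading at this aromatic carbon of the shared core, where 4-(trifluoromethyl)phenyl replaces cyclohexyl. A change at this position therefore joins the earlier change on the saturated chain carbon in staying within the scatter, although here a non-aromatic carbon ring gives way to an aromatic ring bearing fluorine. Nothing measured here explains this result.

On these data alone, whether the read-out would hold with an amine or a carboxylic acid at this aromatic carbon remains open. So does the outcome of a longer chain in the core of compound 1.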